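This account rests on a few compounds, and the source may have more. Where it says the series, first, only, none or still open, it means among the compounds named here.

Working notes on the series, read in an ADME assay on WS1 cells (Homo sapiens) for inhibition, with a stated time of 48 h; a higher number here means a weaker inhibitor, a lower number a stronger inhibitor. Compound 2 `COc1cc2oc(/C=C/[S+](C)[O-])cc(=O)c2cc1OC` gives > 10000 nM, which is a limit of the assay and not a number. Compound 1 `COc1cc2oc(/C=C/[S+](C)[O-])cc(=O)c2cc1O` gives > 10000 nM, again a limit. The series therefore sits largely at the limit of > 10000 nM in this assay, at which 2 of the 3 values shown sit. Compound 3 `COc1ccc2c(=O)cc(/C=C/[S+](C)[O-])oc2c1` gives a number, 9000 nM.

Compound 4 `COc1ccc2oc(/C=C/[S+](C)[O-])cc(=O)c2c1` follows from compound 2 by hydrogen in place of methoxy on an aromatic carbon. The methoxy lost is not the one lost on going to compound 3.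

For the measured compounds named here, two measured steps bear on this change. The closest is an at least 1.1-fold lower number from compound 2 to compound 3 (0.04 log units; that floor lies within the scatter), also a loss of methoxy, and its floor stays within the scatter. The step of an at least 1.1-fold lower number from compound 1 to compound 3 (0.04 log units; that floor lies within the scatter) likewise has a floor within the scatter, while a step that the two limits leave unreadable from compound 1 to compound 2 gives no size. Neither readable floor supports a large change, so no step beyond the scatter is expected, though a small fall in the number remains possible. The expected change is a number no higher from compound 2 to compound 4 (the limit leaves the size open). For compound 4 the estimated value is 10000 nM, with an expected range of 5000 nM to 20000 nM.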

Compound 4, half-maximal inhibitory concentration: 6000 nM
The estimate for compound 4 lay 1.7-fold (0.22 log units) above the measured number, within the range that was stated.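

In this assay, hydrogen in place of this methoxy gives an at least 1.6-fold lower number from compound 2 to compound 4 (0.22 log units; that floor lies within the scatter), and compound 4 carries a readable number where compound 2 stands at a limit. This is the second methoxy of compound 2 whose replacement by hydrogen yields a number, alongside an at least 1.1-fold lower number from compound 2 to compound 3 (0.04 log units; that floor lies within the scatter), so neither methoxy is needed for a readable value in these compounds. The floor of the new step still lies within the scatter, so a change of real size at this position, ortho to a methoxy group, is not established, and the series remains largely at a limit: the limit of > 10000 nM in this assay, at which 2 of the 4 values shown sit.

Steps between two limits cannot be read, and the true distance from compound 2 to compound 4 stays unknown. As far as these compounds go, whether an amine or a longer chain such as ethoxy at this position would move the number beyond the scatter remains open.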